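The source may report more compounds than this note shows. Statements on the series, on what has been measured and on what is new or still open speak of the compounds shown alone.

Compound 1 `Cc1cc(C(=O)O)c(C)n1C` sits at a limit of an assay on cells for inhibition of Palmitoleoyl-protein carboxylesterase NOTUM variant C330S (Homo sapiens), read by fluorescence, with a stated time of 40 min (a lower number here means a stronger inhibitor, a higher number a weaker inhibitor), > 100000 nM, so it gives no number, a point noted in the limit of > 100000 nM in this assay, at which 1 of the 2 values shown sits. Among the measured compounds shown here, compound 2 `Cc1cccc(N2CCC(C(=O)O)C2)c1` is the only compound with a measured number in this assay, where compound 2 gives 49000 nM. Compound 3 `CC(C)c1cccc(N2CCC(C(=O)O)C2)c1` differs from compound 2 by isopropyl in place of methyl on an aromatic carbon. For the measured compounds named here, no measured pair of compounds shows this change, so the size of the step rests on expectation alone. A modest gain in potency is expected, a 2.0-fold lower number from compound 2 to compound 3 (0.29 log units; within the scatter). Compound 3 is therefore estimated at 25000 nM, within a range of 8000 nM to 80000 nM.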

Compound 3, half-maximal inhibitory concentration: 57000 nM
For compound 3 the middle estimate is 2.3-fold (0.36 log units) below the measured one; measured number inside the range.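

In this assay, isopropyl in place of methyl on an aromatic carbon gives a 1.2-fold higher number from compound 2 to compound 3 (0.07 log units; within the scatter). Among the compounds shown here, this is the first measured reading of this change, and it shows that this place on the ring takes the larger isopropyl group with no shift beyond the scatter. The data shown offer no cause for this step.

From the compounds shown here alone, it remains open whether an amine, a trifluoromethyl group or a longer chain at this place would move the number beyond the scatter. Going by these compounds, it also remains open whether the same change would behave alike on another core.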